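A few compounds are considered here, and "the series" means these few. Any claim that something is new, unique, unknown or untested is made for them only; others in the source may bear on it.

The measured compounds:

Compound 1, `O=C(O)[C@H]1NC[C@@H](O)[C@H](O)[C@H]1O`: in an assay for inhibition of alpha-N-acetylgalactosaminidase (Gallus gallus), tested at 1000 uM (a lower number here means less inhibition, a higher number more inhibition at the concentration tested (going by the name of the read-out)), compound 1 gives 4.2%.
Compound 2, `O=C(O)[C@@H]1NC[C@@H](O)[C@@H](O)[C@H]1O`: in this assay compound 2 gives 8.2%.
Compound 3, `O=C(O)[C@H]1NCC=C[C@@H]1O`: in this assay compound 3 gives 25%.

On the numbers shown, compound 2 stands second highest of the three. Its nearest neighbour is compound 1, whose value lies within the scatter of it; the furthest is compound 3, which stands beyond the scatter above it. Going by the values given here, the only measured step that changes configuration alone is a number 4 percentage points higher from compound 1 to compound 2 (within the scatter), a change that rests on (the fact that compounds 1 and 2 differ only in the configuration as drawn).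

Compound 4, `O=C(O)[C@@H]1NC[C@@H](O)[C@H](O)[C@H]1O`, has not yet been tested. It differs from compound 2 as follows: the two compounds have the same atoms and bonds and differ only in configuration as drawn: 1 of 4 stereo elements differ; a stereocentre at a saturated ring carbon is drawn R in compound 2 and S in compound 4. Among the compounds with values here, the step from compound 1 to compound 2 is the one measurement that bears on such a change, and it stayed within the scatter even though two stereocentres were redrawn. For this assay the account therefore expects no step beyond the scatter, and the expected change a number 0.2 percentage points lower from compound 2 to compound 4 (within the scatter) is small. Compound 4 is estimated to give about 8%, within a range from 0% to 25%.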

Compound 4, a percentage reported as inhibition, at one concentration (the size of the read-out at that concentration, not a potency): 1.3%
Beside the measured number, compound 4's estimate is 6.7 percentage points above it, within the range that was stated.
By their numbers in this assay, from the lowest: compounds 4, 1 and 2 (each within the scatter of the next); then compound 3.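

In this assay, changing one stereocentre at a saturated ring carbon gives a number 6.9 percentage points lower from compound 2 to compound 4 (within the scatter), and changing a different one gives a number 2.9 percentage points lower from compound 1 to compound 4 (within the scatter). The earlier compounds shown here showed only two such centres redrawn together, whereas these steps show each centre changed alone, and neither step leaves the scatter. Compounds 1, 2 and 4 therefore cannot be told apart at the concentration tested, and the comparison of compound 1 with compound 4 rests on a purely stereochemical difference: the fact that compounds 1 and 4 differ only in the configuration as drawn

Compound 3, at 25%, differs from these compounds in more than one place, so its value cannot be traced to any single change. Going by these compounds, it remains open whether an acetamido group in place of a hydroxyl, or a methyl ester in place of the carboxylic acid, would move the inhibition beyond the scatter.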